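Methyl to Hydrogen on Two Related Cores

The source may hold more compounds than are shown below. What is called first, only, known or untested is meant among the compounds shown, and "the series" means these compounds.

Measured so far:
compound 1 `Cc1cccc2nc(C#N)c([N+](=O)[O-])n12`: in a physicochemical assay for lipophilicity, measured as octanol-water partition (on this read-out lower numbers stand for lower lipophilicity and higher numbers for higher lipophilicity), compound 1 gives 1.13
compound 2 `Cc1cccc2nc(NC3CCCCC3)c([N+](=O)[O-])n12`: in this assay compound 2 gives 1.5
compound 3 `O=[N+]([O-])c1c(NC2CCCCC2)nc2ccccn12`: in this assay compound 3 gives 1.5

Compound 2 and compound 3 differ in one place, (hydrogen in place of methyl on an aromatic carbon), and the step this makes is no change at the digits printed from compound 2 to compound 3 (within the scatter). Compound 4 `N#Cc1nc2ccccn2c1[N+](=O)[O-]` has not been measured; it differs from compound 1 by hydrogen in place of methyl on an aromatic carbon, the same change at the same place. The difference between the two cores is not broken down here. Among the three measured values, compound 1 stands lowest. Within the data shown here, because no change at the digits printed from compound 2 to compound 3 (within the scatter) is the only guide to this change, the step from compound 1 to compound 4 is expected to be small, a number 0.18 log units lower from compound 1 to compound 4 (within the scatter). For compound 4 the estimated value in this assay is 0.95, with an expected range from 0.55 to 1.35.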

Compound 4, partition coefficient: 0.641
For compound 4 the middle estimate is 0.31 log units above the measured one; the range from low to high includes it.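

In this assay, hydrogen in place of methyl on an aromatic carbon gives a number 0.49 log units lower from compound 1 to compound 4 (beyond the scatter), beyond the scatter, whereas the same change gives no change at the digits printed from compound 2 to compound 3 (within the scatter), within it. The step seen on one core therefore did not carry over in size to the other, though both pairs point to no rise. With one pair on each core, this does not show which difference between the cores matters, and nothing shown here explains the contrast.

The compounds shown leave open how the step would look on a core carrying a carboxylic acid or an amide in place of the nitrile. They also leave open what an ethyl in place of the methyl would give.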